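One Fluorine Less: From Compound 3 to Compound 4

This account rests on a few compounds, and the source may have more. Where it says the series, first, only, none or still open, it means among the compounds named here.

Of the compounds shown here, three sharing one core have been tested in an ADME assay on cells (Astrocyte, Homo sapiens) for cytotoxicity, read by WST assay, with a stated time of 72 h; on this read-out lower numbers stand for stronger inhibition and higher numbers for weaker inhibition. Going by the values given here, compound 3 `O=C(Nc1ccc(C(F)(F)F)cc1)Nc1cc2ncncc2cc1OCc1cccc(F)c1` gives 8900 nM, the highest of the three numbers, though its gaps to compound 1 `O=C(Nc1ccc(Cl)c(Cl)c1)Nc1cc2ncncc2cc1OCc1cccc(F)c1` at 7400 nM and to compound 2 `O=C(Nc1cccc(Cl)c1)Nc1cc2ncncc2cc1OCc1ccccc1` at 7400 nM both fall within the scatter; the one measured step, a 1.2-fold higher number from compound 1 to compound 3 (0.08 log units; within the scatter), is likewise within the scatter. Compound 4 `O=C(Nc1ccc(C(F)(F)F)cc1)Nc1cc2ncncc2cc1OCc1ccccc1` differs from compound 3 by hydrogen in place of fluoro on an aromatic carbon, so that 3-fluorobenzyl becomes benzyl. Among the compounds with values here, no measured pair isolates this change; compound 1 and compound 2 differ in more than one place yet give the same number. The expected step is therefore a 1.0-fold lower number from compound 3 to compound 4 (0.02 log units; within the scatter), nothing beyond the scatter. Compound 4 is estimated at 8500 nM, within 4200 nM to 17000 nM.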

Compound 4, half-maximal inhibitory concentration: 9200 nM
Compound 4: the middle estimate sits 1.1-fold (0.03 log units) below what was measured; measured number inside the range.
By their numbers in this assay, from the lowest: compounds 1, 2, 3 and 4 (each within the scatter of the next).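

The fluoro on the 3-fluorobenzyl group can now be judged on its own: in this assay replacing it with hydrogen gives a 1.0-fold higher number from compound 3 to compound 4 (0.01 log units; within the scatter) for this single change. With benzyl held constant, the aryl change gives a 1.2-fold higher number from compound 2 to compound 4 (0.09 log units; within the scatter) and so also does not separate the two compounds. No measurement here offers an explanation for either step. Going by these compounds, whether an amine or a carboxylic acid on this aromatic carbon would move the number beyond the scatter remains open. So does whether a longer chain in place of benzyl would do so.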